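Swapping pyridin-2-yl on the amino nitrogen

The compounds below may be only part of what the source reports. "The series", "measured", "known", "first", "only" and "open" are said of these compounds alone.

For the measured compounds named here, in a functional assay on GOTO cells (Homo sapiens) for cytotoxicity, read by MTT assay, with a stated time of 3 days (on this read-out lower numbers stand for stronger inhibition and higher numbers for weaker inhibition), compound 2 `N#Cc1c(Nc2ccccn2)nc(SCc2nc3ccccc3[nH]2)nc1-c1ccccc1` gives 2.5 nM, the lowest of the two numbers so far, and compound 1 `N#Cc1c(O)nc(SCc2nc3ccccc3[nH]2)nc1-c1ccccc1` gives 7.81 nM. Compound 3 `N#Cc1c(NC(N)=S)nc(SCc2nc3ccccc3[nH]2)nc1-c1ccccc1` differs from compound 2 by a group of 3 heavy atoms (1 carbon, 1 nitrogen, 1 sulfur; no ring) in place of a group of 6 heavy atoms (5 carbon, 1 nitrogen; one six-membered aromatic ring with 1 hetero atom), on a nitrogen on an aromatic ring. Going by the values given here, the only measured step bearing on this change is a 3.1-fold lower number from compound 1 to compound 2 (0.49 log units; beyond the scatter), which brought in the pyridin-2-yl group in place of hydroxy and is modest. A step of no greater size is therefore expected, towards a higher number in this assay. The estimated step is a 2.0-fold higher number from compound 2 to compound 3 (0.30 log units; within the scatter). Compound 3 is expected at 5 nM, with an estimated range of 1.5 nM to 15 nM.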

Compound 3, half-maximal inhibitory concentration: 4.8 nM
For compound 3 the middle estimate is 1.0-fold (0.02 log units) above the measured one; the measured number falls inside the stated range.
By their numbers in this assay, from the lowest: compounds 2, 3 and 1 (each within the scatter of the next, the first and the last beyond it).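

In this assay the swap of pyridin-2-yl for the group with no ring on the amino nitrogen gives a 1.9-fold higher number from compound 2 to compound 3 (0.28 log units; within the scatter) and so the aromatic ring on this nitrogen is not shown to be needed. Replacing hydroxy on the aromatic carbon with this open group gives a 1.6-fold lower number from compound 1 to compound 3 (0.21 log units; within the scatter) and so the new compound cannot be separated from either neighbour, although the pyridin-2-yl and hydroxy compounds stand apart. Nothing available explains these numbers.

Open, on these data alone, is whether a plain amine, or an acetyl group on this nitrogen, would stay in the same range. Also open, as far as these compounds go, is how a longer alkyl chain or a phenyl ring would read here.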